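Benzamide aryl variation in a sulfonamide-linked CXCR4 series

The compounds below may be only part of what the source reports. "The series", "measured", "known", "first", "only" and "open" are said of these compounds alone.

Of the compounds shown here, two have been measured so far. Compound 1 `COc1cccc(C(=O)NCc2ccc(CNS(=O)(=O)c3ccc(C)cc3)cc2)c1` carries a 3-methoxyphenyl on the amide carbonyl and a 4-methylphenyl on the sulfonyl group. In an assay on MDA-MB-231 cells for binding affinity to C-X-C chemokine receptor type 4 (Homo sapiens), read by immunofluorescence and microscopy, with stated times of 10 min and 30 min (a higher number here means that more compound is needed for the effect, a lower number that less compound is needed), compound 1 gives 10 nM, the lowest of the two numbers in hand. Compound 2 `Cc1cccc(C(=O)NCc2ccc(CNS(=O)(=O)c3ccccc3)cc2)c1` differs from compound 1 in two places at once, both on the benzamide aryl and on the sulfonyl aryl, so the two cannot be compared through a single change; in this assay compound 2 gives 1000 nM, which lies well beyond the scatter from compound 1.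

Compound 3 `Cc1ccc(C(=O)NCc2ccc(CNS(=O)(=O)c3ccc(C)cc3)cc2)cc1` is the next candidate for this assay. Relative to compound 1 the change is 4-methylphenyl in place of 3-methoxyphenyl on a carbonyl carbon, with the sulfonyl aryl left untouched. Among the compounds with values here, because compound 2 gives 1000 nM after a change that also touches the benzamide aryl, some loss is expected for compound 3, though the size is uncertain with no single-change step available. The step from compound 1 to compound 3 is estimated at a 5.0-fold higher number from compound 1 to compound 3 (0.70 log units; beyond the scatter), beyond the scatter. Compound 3 is expected to give about 50 nM, within 10 nM to 300 nM.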

Compound 3, effective concentration (reported as EC, without a stated level of effect): 1000 nM
Beside the measured number, compound 3's estimate is 20-fold (1.30 log units) below it; measured number above the stated range.
By their numbers in this assay, from the lowest: compound 1; then compounds 2 and 3 (each within the scatter of the next).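

With the sulfonyl aryl held constant, the series now has its first single-change step in this assay: 4-methylphenyl in place of 3-methoxyphenyl on a carbonyl carbon gives a 100-fold higher number from compound 1 to compound 3 (2.00 log units; beyond the scatter) and counts as a large step. This shows that the aryl on the carbonyl carbon alone can move the number well beyond the scatter, which the two-place difference between compound 1 and compound 2 could not show. The exchange alters the substituent and its printed place together, and it also takes away the one hydrogen-bond acceptor of the leaving group, so this pair does not separate these differences; no measurement shown here bears on the origin of the step.

The effect of the sulfonyl aryl alone cannot be read from these compounds, and neither can the separate contributions of the substituent's identity and its place on the benzamide aryl. On these data alone, it also remains open how this position would respond to an amine or a carboxylic acid on the benzamide aryl, or to a longer alkoxy chain in place of the methoxy group.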